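This account rests on a few compounds, and the source may have more. Where it says the series, first, only, none or still open, it means among the compounds named here.

Going by the values given here, compound 1 `CCC/C=C/C(=O)N(Cc1ccc(OC)c(O)c1)c1cc(OC)c(OC)c(OC)c1` gives 70 nM in a functional assay on MGC-803 cells (Homo sapiens) for inhibition, read by MTT assay, with a stated time of 48 h (a higher number here means a weaker inhibitor, a lower number a stronger inhibitor), the lowest of the two numbers measured so far. Compound 2 `C/C=C/C(=O)N(Cc1ccc(OC)c(C)c1)c1cc(OC)c(OC)c(OC)c1` gives 14500 nM in this assay, a far weaker result, though the two structures differ in more than one place. Compound 3 `COc1ccc(CN(C(=O)CCCl)c2cc(OC)c(OC)c(OC)c2)cc1O` has not yet been measured in this assay. It differs from compound 1 by one change (2-chloroethyl in place of pent-1-en-1-yl on a carbonyl carbon). Among the compounds with values here, no measured pair shows this change, so its effect is open, and a moderate weakening is expected, a 3.6-fold higher number from compound 1 to compound 3 (0.55 log units; beyond the scatter), with a wide range. Compound 3 is estimated at 250 nM in this assay, between 40 nM and 2000 nM.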

Compound 3, half-maximal inhibitory concentration: 140 nM
Compound 3: middle estimate off by 1.8-fold (0.25 log units), on the high side; low and high end bracket the measured number.
By their numbers in this assay, from the lowest: compounds 1 and 3 (each within the scatter of the next); then compound 2.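

Placing 2-chloroethyl in place of pent-1-en-1-yl on a carbonyl carbon gives a 2.0-fold higher number from compound 1 to compound 3 (0.30 log units; within the scatter) in this assay and so leaves the reading within the scatter. Going by these compounds alone, this is the first step that can be read at this position, and it shows that the position accepts a chain with fewer carbons, a chlorine and no double bond. No measurement at hand explains why these two groups read alike.

Within the data shown here, with only two groups compared, the separate roles of the chlorine and the chain length stay open. So does the outcome with an amine or a carboxylic acid on this carbonyl carbon.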